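A few compounds are considered here, and "the series" means these few. Any claim that something is new, unique, unknown or untested is made for them only; others in the source may bear on it.

Compound 1 `CCn1c(C(=O)NCCN(C)C)ccc1C(CC)(CC)c1ccc(OCC(O)C(C)(C)C)c(C)c1` gives the lowest of the two numbers shown: in a functional assay on PC-3 cells (Homo sapiens), read by MTT assay, with a stated time of 48 h (on this read-out lower numbers stand for stronger inhibition and higher numbers for weaker inhibition), compound 1 gives 1630 nM. Among the compounds with values here, its one measured neighbour, compound 2 `CCn1c(C(=O)NCCCN(C)C)ccc1C(CC)(CC)c1ccc(OCC(O)C(C)(C)C)c(C)c1`, gives 3100 nM in this assay, and the step of a 1.9-fold higher number from compound 1 to compound 2 (0.28 log units; within the scatter). Compound 3 `C#CC(C)OC(=O)c1ccc(C(CC)(CC)c2ccc(OCC(O)C(C)(C)C)c(C)c2)n1CC` has not been measured in this assay. It differs from compound 1 in a single place: (1-methylprop-2-yn-1-yl)oxy in place of (2-(dimethylamino)ethyl)amino on a carbonyl carbon. Within the data shown here, the only measured step, from compound 1 to compound 2, alters the chain carrying the dimethylamino group while keeping the amide, so it does not speak to swapping the whole (2-(dimethylamino)ethyl)amino group for (1-methylprop-2-yn-1-yl)oxy. Among the measured compounds shown here, with no step bearing directly on this change, the expectation for compound 3 is a wide one, centred on a somewhat weaker number and expressed as a 1.8-fold higher number from compound 1 to compound 3 (0.26 log units; within the scatter). Compound 3 is estimated at 3000 nM, within a range from 700 nM to 13000 nM.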

Compound 3, half-maximal inhibitory concentration: 38200 nM
Compound 3: the middle estimate sits 13-fold (1.10 log units) below what was measured; the measured number lies above the stated range.
By their numbers in this assay, from the lowest: compounds 1 and 2 (each within the scatter of the next); then compound 3.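

In this assay, what sits on the carbonyl carbon proves to matter much more than the earlier chain change suggested: (1-methylprop-2-yn-1-yl)oxy in place of (2-(dimethylamino)ethyl)amino gives a 23-fold higher number from compound 1 to compound 3 (1.37 log units; beyond the scatter), whereas lengthening the chain stayed within the scatter. Measured against the (3-(dimethylamino)propyl)amino group, the same position gives a 12-fold higher number from compound 2 to compound 3 (1.09 log units; beyond the scatter), so the weaker inhibition appears with either chain as the starting point. Nothing available explains the size of these steps.

This single swap removes the amide nitrogen and the dimethylamino group and brings in a triple bond all at once, so the compounds shown cannot say which of these changes counts. A (2-(dimethylamino)ethyl)oxy group or a carboxylic acid on the carbonyl carbon would help pull these changes apart.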